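The compounds below may be only part of what the source reports. "The series", "measured", "known", "first", "only" and "open" are said of these compounds alone.

Measured compounds:
compound 1, `Cc1n[nH]c2c1C(c1ccc(N(C)C)cc1)C(C(N)=O)=C(N)N2`: 4550 nM
compound 2, `Cc1n[nH]c2c1C(c1ccc(N(C)C)cc1)C(C(=O)N/N=C/c1ccc(Cl)cc1)=C(N)N2`: 25200 nM

In a functional assay on MCF7 cells (Homo sapiens) for cytotoxicity, read by MTT assay, with a stated time of 48 h (on this read-out higher numbers stand for weaker inhibition and lower numbers for stronger inhibition), compound 1 gives the lowest of the two numbers; the only other is a 5.5-fold higher number from compound 1 to compound 2 (0.74 log units; beyond the scatter). Compound 3 is `Cc1n[nH]c2c1C(c1ccc(N(C)C)cc1)C=C(N)N2`. It differs from compound 1 in that (hydrogen in place of carbamoyl on a double-bonded ring carbon). Among the measured compounds shown here, no measured step removes the carbamoyl; the one step known alters it instead, so it gives only a weak hint that changing this group tends to raise the number. Compound 3 is therefore expected to show a modest rise, a 2.0-fold higher number from compound 1 to compound 3 (0.30 log units; within the scatter), with wide uncertainty. The estimate for compound 3 is 9000 nM, within a range of 3000 nM to 30000 nM.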

Compound 3, half-maximal inhibitory concentration: 11200 nM
For compound 3 the middle estimate is 1.2-fold (0.09 log units) below the measured one; the measured number falls inside the stated range.
By their numbers in this assay, from the lowest: compound 1; then compound 3; then compound 2.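

Replacing the carbamoyl with hydrogen on this double-bonded ring carbon in this assay gives a 2.5-fold higher number from compound 1 to compound 3 (0.39 log units; beyond the scatter) and so shows that removing the group, not only enlarging it on its nitrogen, raises the number. Compound 3 still gives a measured number without any group at this carbon, so the carbamoyl is not needed for a reading in this test. Nothing available explains this rise. From the compounds shown here alone, whether a nitrile, a carboxylic acid or a methyl ester on this carbon would lower the number below that of compound 1 stays open.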